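This account rests on a few compounds, and the source may have more. Where it says the series, first, only, none or still open, it means among the compounds named here.

Of the compounds shown here, two have numbers so far. Compound 1 `[O-]c1on[n+](-c2ccc(Cc3ccc(-[n+]4noc([O-])c4CN4CCN(c5ccccc5)CC4)cc3)cc2)c1CN1CCN(c2ccccc2)CC1` and compound 2 `Cc1ccc(-[n+]2noc([O-])c2CN2CCNCC2)cc1` were tested in an ADME assay on HEL cells (Homo sapiens) for cytotoxicity; a higher number here means that more compound is tolerated, a lower number that less compound is tolerated. In this assay compound 1 gives 12 ug/mL, and compound 2 gives 46 ug/mL, the higher of the two numbers and beyond the scatter of compound 1. Compound 3 `Cc1ccc(-[n+]2noc([O-])c2CN2CCN(c3cccc(Cl)c3)CC2)cc1` is not yet measured. It differs from compound 2 by 3-chlorophenyl in place of hydrogen on an amine nitrogen in a ring. Among the compounds with values here, no measured pair shows this change on its own, so its size is open. A lower number is expected for compound 3, because compound 1, whose ring amine nitrogens both already carry a group of this kind, gives 12 ug/mL. The step of a 1.8-fold lower number from compound 2 to compound 3 (0.26 log units; within the scatter) is expected to be modest. Compound 3 is estimated at 25 ug/mL, within 10 ug/mL to 60 ug/mL.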

Compound 3, half-maximal cytotoxic concentration: 38.2 ug/mL
Compound 3: the middle estimate sits 1.5-fold (0.18 log units) below what was measured; measured number inside the range.
By their numbers in this assay, from the lowest: compound 1; then compounds 3 and 2 (each within the scatter of the next).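

Within the data shown here, replacing hydrogen with 3-chlorophenyl on the amine nitrogen in the ring, a first direct reading of this change, gives a small step in this assay (a 1.2-fold lower number from compound 2 to compound 3 (0.08 log units; within the scatter)). At this position, then, the added aromatic ring and its chlorine leave compound 2 and compound 3 within the scatter of each other. Nothing available here explains this result.

From the compounds shown here alone, what a methyl group or a longer alkyl chain would do on the same nitrogen remains open. So does whether a carboxylic acid on such a chain would give a step beyond the scatter.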